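This account rests on a few compounds, and the source may have more. Where it says the series, first, only, none or still open, it means among the compounds named here.

Among the measured compounds shown here, compound 2 `COCOc1ccc(CN(Cc2ccc(C(C)(C)C)cc2)Cc2cc3cc(C)ccc3[nH]c2=O)cc1` is the only compound here with a plain number. In a toxicity assay on MDCK cells (Canis lupus familiaris) for cytotoxicity, read by crystal violet staining, with a stated time of 48 h (on this read-out lower numbers stand for higher toxicity in this test and higher numbers for lower toxicity in this test), compound 2 gives 6400 nM. Compound 1 `CCc1ccc2[nH]c(=O)c(CN(CCCO)Cc3ccc(C(C)(C)C)cc3)cc2c1` reaches only a limit of the test in this assay, > 10000 nM, as the limit of > 10000 nM in this assay, at which 1 of the 2 values shown sits, records. Compound 3 `CCc1ccc2[nH]c(=O)c(CN(Cc3ccc(OCOC)cc3)Cc3ccc(C(C)(C)C)cc3)cc2c1` is made from compound 2 by a single change: methyl in place of hydrogen on a saturated chain carbon bound to an aromatic carbon. For the measured compounds named here, no measured pair shows what this change does in this assay, so only a step within the usual scatter is expected, a 1.3-fold lower number from compound 2 to compound 3 (0.11 log units; within the scatter). Compound 3 is therefore estimated at 5000 nM, within a range from 2000 nM to 12000 nM.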

Compound 3, half-maximal cytotoxic concentration: > 10000 nM
Compound 3: only a limit was reported; the forecaster's own chance of this, stated with the estimate: 35%; middle value at least 2.0-fold (0.30 log units) away from the limit.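

In this assay, among the compounds shown here, this pair gives an at least 1.5-fold higher number from compound 2 to compound 3 (0.19 log units; that floor lies within the scatter) as the first measured reading of methyl in place of hydrogen on a saturated chain carbon bound to an aromatic carbon. Compound 3 carries a limit rather than a number, and the step is only a floor within the scatter, so the change may do little or more. The step between compound 1 and compound 3 cannot be read, and the limit now recurs: the limit of > 10000 nM in this assay, at which 2 of the 3 values shown sit.

Open, on these data alone, is how far the true value of compound 3 lies past that floor. Also open, as far as these compounds go, is what a longer chain, an amine or a carboxylic acid would do at this place.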